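The source may report more compounds than this note shows. Statements on the series, on what has been measured and on what is new or still open speak of the compounds shown alone.

In a functional assay on A549 cells (Homo sapiens) for antiproliferative activity, read by MTT assay, with a stated time of 48 h (a higher number here means a weaker inhibitor, a lower number a stronger inhibitor), compound 2 `COC(=O)CN(C)c1nc(Nc2ccc(Cl)cc2)ncc1[N+](=O)[O-]` gives 23500 nM and stands lowest of the two numbers measured, though compound 3 `COC(=O)CN(C)c1nc(Nc2cccc(OC)c2)ncc1[N+](=O)[O-]` gives 31900 nM and the two cannot really be told apart. Within the data shown here, the only measured step between neighbours, a 1.4-fold higher number from compound 2 to compound 3 (0.13 log units; within the scatter), lies within the scatter. Compound 1 `CCOC(=O)CN(Cc1ccccc1)c1nc(NCc2ccccc2)ncc1[N+](=O)[O-]` gives only a limit in this assay, > 100000 nM. Among the measured compounds shown here, this is the single value sitting at the limit of > 100000 nM in this assay, at which 1 of the 3 values shown sits. Compound 1 differs from compound 2 in several places at once, so its result cannot be read as a step on its own.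

Compound 4 `CCOC(=O)CNc1nc(Nc2ccc(Cl)cc2)ncc1[N+](=O)[O-]` has not yet been measured in this assay. It differs from compound 2 in one place: ((ethoxycarbonyl)methyl)amino in place of ((methoxycarbonyl)methyl)(methyl)amino on an aromatic carbon. For the measured compounds named here, no measured step touches this part of the shared core; the one step that is known changes the aryl group on a nitrogen on an aromatic ring and stays within the scatter. Going by the values given here, there is thus no precedent to lean on, and the expectation is a step of a 1.1-fold higher number from compound 2 to compound 4 (0.03 log units; within the scatter) in this assay, not beyond the scatter. Compound 4 is therefore estimated at 25000 nM, with a plausible range from 8000 nM to 80000 nM.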

Compound 4, half-maximal inhibitory concentration: > 100000 nM
Compound 4: no number, only a limit; the forecaster's own chance of this, stated with the estimate: 20%; middle value at least 4.0-fold (0.60 log units) away from the limit.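

Among these compounds, changing the group on the aromatic carbon ortho to a nitro group can move the result in this assay: the swap to ((ethoxycarbonyl)methyl)amino gives an at least 4.2-fold higher number from compound 2 to compound 4 (0.62 log units; beyond the scatter), whereas the only earlier step, made at the aryl group, gave a 1.4-fold higher number from compound 2 to compound 3 (0.13 log units; within the scatter). From the compounds shown here alone, the result for compound 4 is a limit and not a number, and the real size of that step stays unknown. The swap keeps the same heavy atoms, yet it removes the methyl from the nitrogen, turns the methyl ester into an ethyl ester and brings 1 hydrogen-bond donor where there were 0, and limit results now recur in this series: the limit of > 100000 nM in this assay, at which 2 of the 4 values shown sit.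

Which part of the swap counts stays open, since the methyl on the nitrogen and the ester change together, and only a compound carrying ((methoxycarbonyl)methyl)amino, with the ester kept as the methyl ester and the nitrogen free of its methyl, could begin to separate them. The compounds shown also do not tell how a carboxylic acid or an amide in place of the ester, or a longer chain on the nitrogen, would read at this position.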